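The source may report more compounds than this note shows. Statements on the series, on what has been measured and on what is new or still open speak of the compounds shown alone.

Measured so far in a functional assay on HepG2 cells (Homo sapiens) for antiproliferative activity, read by spectrophotometry, with a stated time of 2 days; a higher number here means a weaker inhibitor of growth, a lower number a stronger inhibitor of growth:
- compound 1 `Cc1ccc(Nc2ncc(C(F)(F)F)c(N3Cc4cccc(N(C)S(C)(=O)=O)c4C3)n2)c(Cl)c1`: > 30000 nM
- compound 2 `CN(c1cccc2c1CN(c1nc(Nc3ccc(Nc4ccccc4)cc3)ncc1C(F)(F)F)C2)S(C)(=O)=O`: 8600 nM

Compound 1 stands at the limit of > 30000 nM in this assay, at which 1 of the 2 values shown sits; this is a limit, not a number.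

Compound 3 `Cc1cc(C)cc(Nc2ncc(C(F)(F)F)c(N3Cc4cccc(N(C)S(C)(=O)=O)c4C3)n2)c1` has 3,5-dimethylphenyl in place of 2-chloro-4-methylphenyl on a nitrogen on an aromatic ring.

Among the measured compounds shown here, no measured step covers this change. Compound 2, at 8600 nM, shows only that the series can give a number in this assay. A modest move towards stronger inhibition is expected, with the estimated step of an at least 1.5-fold lower number from compound 1 to compound 3 (0.17 log units; that floor lies within the scatter). Compound 3 is estimated at 20000 nM, with an expected range of 7000 nM to 45000 nM.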

Compound 3, concentration for 50% growth inhibition: > 30000 nM
Compound 3 was reported as a limit (the forecaster's own chance of this, stated with the estimate: 50%); at least 1.5-fold (0.17 log units) between middle value and limit.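

No step can be read from compound 1 to compound 3, since both are reported only as a limit, not a number: the limit of > 30000 nM in this assay, at which 2 of the 3 values shown sit.

As far as these compounds go, whether 3,5-dimethylphenyl or 2-chloro-4-methylphenyl on that nitrogen gives stronger inhibition of growth remains open.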